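The source may hold more compounds than are shown below. What is called first, only, known or untested is meant among the compounds shown, and "the series" means these compounds.

Compound 2 `COc1cccc(COc2ccc3c(Cn4ccnc4)cc(=O)oc3c2)c1` gives 2% in an assay for inhibition of steroid 17-alpha-hydroxylase/17,20 lyase (Homo sapiens), read by HPLC, with a stated time of 5 min, tested at 2.5 uM, in the presence of a further agent that is not named here (a higher number here means more inhibition at the concentration tested (going by the name of the read-out), a lower number less inhibition), a number that sits within the usual scatter of both its neighbours: compound 1 `O=c1cc(Cn2ccnc2)c2ccc(OCc3cccc(C(F)(F)F)c3)cc2o1` gives 0% in this assay, and compound 3 `COc1ccc(COc2ccc3c(Cn4ccnc4)cc(=O)oc3c2)cc1OC` gives 0% in this assay. The two measured steps are small, a number 2 percentage points higher from compound 1 to compound 2 (within the scatter) and a number 2 percentage points lower from compound 2 to compound 3 (within the scatter), and both concern a group on the benzyl ring. Compound 4 `Cc1cccc(COc2ccc3c(Cn4ccnc4)cc(=O)oc3c2)c1` differs from compound 2 by methyl in place of methoxy on an aromatic carbon. Since every change at that ring so far, a number 2 percentage points higher from compound 1 to compound 2 (within the scatter) and a number 2 percentage points lower from compound 2 to compound 3 (within the scatter), has stayed inside the scatter, no shift beyond the scatter is expected here either, and the estimated step is no change at the digits printed from compound 2 to compound 4 (within the scatter). Compound 4 is therefore expected to give about 2%, between 0% and 12%.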

Compound 4, a percentage reported as inhibition, at one concentration (the size of the read-out at that concentration, not a potency): 0%
Estimate against measurement, compound 4: 2 percentage points above; the range from low to high includes it.
By their numbers in this assay, from the lowest: compounds 1, 3, 4 and 2 (each within the scatter of the next).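

With methyl, a group with no hydrogen-bond acceptor, replacing methoxy, this assay shows a number 2 percentage points lower from compound 2 to compound 4 (within the scatter), and methyl replacing trifluoromethyl shows no change at the digits printed from compound 1 to compound 4 (within the scatter). At this ring position, then, methyl, methoxy and trifluoromethyl cannot be told apart in this read-out, and the acceptor of the methoxy group makes no difference beyond the scatter. Nothing at hand gives a reason for this flatness.

On these data alone, whether an amine or a carboxylic acid at this position would lift the number clear of the scatter stays open. So does whether any change away from the benzyl ring would do so.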